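Methyl in Place of Hydrogen: Compound 3 to Compound 4

The compounds below may be only part of what the source reports. "The series", "measured", "known", "first", "only" and "open" are said of these compounds alone.

Compound 1, `C=C(Cl)C(=O)Nc1cc(Nc2nccc(-c3cn(C)c4ccccc34)n2)c(OC)cc1N(C)CCN(C)C`, gives 1390 nM in a functional assay on HepG2 cells (Homo sapiens) for antiproliferative activity, read by MTT assay, with a stated time of 72 h; on this read-out higher numbers stand for weaker inhibition and lower numbers for stronger inhibition.
Compound 2, `C=C(Cl)C(=O)Nc1cc(Nc2nc(C)cc(-c3cn(C)c4ccccc34)n2)c(OC)cc1N(C)CCN(C)C`, gives 3640 nM in this assay.
Compound 3, `C=CC(=O)Nc1cc(Nc2nccc(-c3cn(C)c4ccc(F)cc34)n2)c(OC)cc1N(C)CCN(C)C`, gives 429 nM in this assay.

Compound 3 stands lowest of the three, and its gaps to compound 1 and to compound 2 are both beyond the scatter. Among the measured compounds shown here, the one step measured within a single core is methyl in place of hydrogen on an aromatic carbon, which brought a 2.6-fold higher number from compound 1 to compound 2 (0.42 log units; beyond the scatter). The difference between the core of compound 1 and the core of compound 3 is not broken down here.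

Compound 4, `C=CC(=O)Nc1cc(Nc2nc(C)cc(-c3cn(C)c4ccc(F)cc34)n2)c(OC)cc1N(C)CCN(C)C`, is not yet measured. It differs from compound 3 by methyl in place of hydrogen on an aromatic carbon. This is the same kind of change as that from compound 1 to compound 2, though the surroundings differ: in compound 4 the methyl is meta to a 5-fluoro-1-methyl-1H-indol-3-yl group, whereas in compound 2 it is meta to a 1-methyl-1H-indol-3-yl group.

In this assay, for the measured compounds named here, compound 4 is expected to show a 2.6-fold higher number from compound 3 to compound 4 (0.41 log units; beyond the scatter), a step of about the size seen as a 2.6-fold higher number from compound 1 to compound 2 (0.42 log units; beyond the scatter), since that is the only measured instance of this change. Compound 4 is therefore estimated at 1100 nM, with an expected range from 500 nM to 2600 nM.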

Compound 4, half-maximal inhibitory concentration: 4280 nM
Compound 4: middle estimate off by 3.9-fold (0.59 log units), on the low side; the whole stated range lies below it.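

The methyl again gave a higher number in this assay, with a 10-fold higher number from compound 3 to compound 4 (1.00 log units; beyond the scatter), so the direction of the change carried over from one core to the other. Its size did not carry over: the same change on two cores in this assay, a 2.6-fold higher number (0.42 log units; beyond the scatter) from compound 1 to compound 2 and a 10-fold higher number (1.00 log units; beyond the scatter) from compound 3 to compound 4, 3.8-fold (0.58 log units) apart, beyond the scatter of two such steps. Among the compounds shown here, these two pairs show only that the change went the same way twice; they do not show which difference between the core of compound 1 and the core of compound 3 sets the two steps apart, and they give no general rule for the series.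

The compounds shown leave open how an ethyl, a methoxy or an amine on the same aromatic carbon would compare with hydrogen and methyl. Also open, on these data alone, is how the step would run on a core differing from that of compound 3 in one place only, which could separate the part played by the fluoro of the 5-fluoro-1-methyl-1H-indol-3-yl group from the other difference between the cores.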